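The source may report more compounds than this note shows. Statements on the series, on what has been measured and on what is new or still open speak of the compounds shown alone.

Compound 1, with the structure `CNC(=O)c1cc(C(=O)NC2CC2)cn(CC2CCCOC2)c1=O`, is the starting point of this comparison. In a physicochemical assay for solubility (on this read-out higher numbers stand for higher solubility and lower numbers for lower solubility), compound 1 reaches only a limit of the measurement, recorded as >= 131 ug/mL, so its true value is not a number but (the limit of >= 131 ug/mL in this assay, at which 1 of the 3 values shown sits). Compound 2, with the structure `CNC(=O)c1cccn(Cc2ccccc2)c1=O`, gives a measured number in this assay, 78 ug/mL. Compound 3, with the structure `CNC(=O)c1cc(C(=O)NC2CC2)cn(Cc2cccc3[nH]c(C)nc23)c1=O`, also stops at a limit in this assay, recorded as >= 198 ug/mL, which is the limit of >= 198 ug/mL in this assay, at which 1 of the 3 values shown sits. Against these three values, compound 1 sits at the limit rather than at a measured point, and no step between two measured compounds is available to calibrate a change.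

The compound still to be measured is compound 4, with the structure `CNC(=O)c1cc(C(=O)NC2CC2)cn(Cc2nccc3[nH]ccc23)c1=O`. It differs from compound 1 in one place: a group of 9 heavy atoms (7 carbon, 2 nitrogen; one five-membered aromatic ring with 1 hetero atom, one six-membered aromatic ring with 1 hetero atom) in place of a group of 6 heavy atoms (5 carbon, 1 oxygen; one six-membered non-aromatic ring with 1 hetero atom), on a saturated chain carbon bound to an aromatic nitrogen. Compound 3 carries a comparably large aromatic two-ring group on the same saturated chain carbon and still reaches the limit >= 198 ug/mL, so compound 4 is expected to stay close to compound 1, with a step from compound 1 to compound 4 of a step that the limit leaves unreadable from compound 1 to compound 4, within the usual scatter. The solubility of compound 4 is therefore estimated at 150 ug/mL, with a likely range from 60 ug/mL to 300 ug/mL.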

Compound 4, solubility: 73 ug/mL
Beside the measured number, compound 4's estimate is 2.1-fold (0.31 log units) above it; measured number inside the range.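

In this assay, placing the two-ring aromatic group on the saturated chain carbon bound to an aromatic nitrogen, where oxan-3-yl stood, gives an at least 1.7-fold lower number from compound 1 to compound 4 (0.25 log units; that floor lies within the scatter). Going by these compounds alone, this is the first step at this position that can be read at all, but it is only a floor, and the real size of the change stays unknown: the limit of >= 131 ug/mL in this assay, at which 1 of the 4 values shown sits. Compound 3, with a different aromatic two-ring group at the same place, also stops at a limit, so two such groups cannot be set against each other as numbers: the limit of >= 198 ug/mL in this assay, at which 1 of the 4 values shown sits.

As far as these compounds go, it stays open which part of the entering group the step belongs to: the five-membered ring, the six-membered ring or the added hydrogen-bond donor. From the compounds shown here alone, how an amine or a carboxylic acid on the same saturated chain carbon would read in this assay also stays open.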